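The source may hold more compounds than are shown below. What is called first, only, known or untested is meant among the compounds shown, and "the series" means these compounds.

- compound 1 `CCCSc1nc(N/N=C/c2cccs2)c2nnn(Cc3ccccc3)c2n1`: > 64000 nM
- compound 2 `CCCSc1nc(N/N=C(\C)c2ccccc2O)c2nnn(Cc3cccc(Cl)c3)c2n1`: 6500 nM
- compound 3 `CCCSc1nc(N/N=C(\C)c2ccccc2O)c2nnn(Cc3ccc(Br)cc3)c2n1`: 11300 nM

All three results come from a functional assay on MGC-803 cells (Homo sapiens) for antiproliferative activity, read by MTT assay, with a stated time of 72 h; a lower number here means a stronger inhibitor, a higher number a weaker inhibitor. Compound 1 gives no number, only a limit of the assay: the limit of > 64000 nM in this assay, at which 1 of the 3 values shown sits.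

Next comes compound 4 `CCCSc1nc(N/N=C/c2ccccc2F)c2nnn(Cc3ccccc3)c2n1`, which has 2-fluorophenyl in place of thiophen-2-yl on a carbon with a double bond to nitrogen.

Among the compounds with values here, no measured step covers this exchange. The only one available is a 1.7-fold higher number from compound 2 to compound 3 (0.24 log units; within the scatter). It concerns 4-bromophenyl in place of 3-chlorophenyl on a saturated chain carbon bound to an aromatic nitrogen, so it does not bear directly on the change at hand. Compound 2 at 6500 nM also differs from compound 1 on the carbon with a double bond to nitrogen, so it serves only as a loose guide to where a number might fall in this assay.

The expected result is a modest move towards a lower number, an at least 2.1-fold lower number from compound 1 to compound 4 (0.32 log units; beyond the scatter), and this estimate is uncertain. A second result reported only as a limit would not be surprising. The estimated value for compound 4 is 30000 nM, with an expected range of 10000 nM to 64000 nM.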

Compound 4, half-maximal inhibitory concentration: > 64000 nM
Compound 4 gave a limit, no number; the forecaster's own chance of this, stated with the estimate: 40%; middle value at least 2.1-fold (0.32 log units) away from the limit.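

In this assay, compound 1 and compound 4 both give only a limit, so no step can be read between them: the limit of > 64000 nM in this assay, at which 2 of the 4 values shown sit. The compounds shown leave open how 2-fluorophenyl and thiophen-2-yl compare on a carbon with a double bond to nitrogen.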